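A Chloro for a Hydroxy on the Phenyl Ring

The source may report more compounds than this note shows. Statements on the series, on what has been measured and on what is new or still open speak of the compounds shown alone.

Compound 1 `CN1CCN(c2nc(-c3cccc(O)c3)nc3c2ncn3C)CC1` stands highest of the two measured compounds in an assay on cells for displacement of a labelled ligand from adenosine receptor A2b (Homo sapiens), read by scintillation counting and radioligand binding, with a stated time of 30 min, tested at 10 uM (on this read-out lower numbers stand for less inhibition and higher numbers for more inhibition at the one concentration tested (going by the name of the read-out)), where compound 1 gives 47.8%. Compound 2 `Cn1cnc2c(N3CCCCC3)nc(-c3cccc(O)c3)nc21` gives 29.3% in this assay, and the step of a number 18.5 percentage points lower from compound 1 to compound 2 (beyond the scatter) lies beyond the scatter, so the number for compound 1 is the higher of the pair. Compound 3 `CN1CCN(c2nc(-c3cccc(Cl)c3)nc3c2ncn3C)CC1` differs from compound 1 in a single place: chloro in place of hydroxy on an aromatic carbon. For the measured compounds named here, no measured step touches this part of the molecule; the only step known, from compound 1 to compound 2, concerns a different group on the shared core and therefore gives no guidance on the replacement of hydroxy by chloro. With no comparison to lean on, the expected step of a number 9.8 percentage points lower from compound 1 to compound 3 (within the scatter) is set modest in size and its direction is uncertain, which calls for a wide range around the estimate. Compound 3 is therefore expected to give about 38% in this assay, with a range from 8% to 68%.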

Compound 3, a percentage reported as inhibition, at one concentration (the size of the read-out at that concentration, not a potency): 19.2%
Compound 3: the middle estimate sits 18.8 percentage points above what was measured, within the range that was stated.
By their numbers in this assay, from the lowest: compound 3; then compound 2; then compound 1.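

In this assay, the group on the phenyl ring turns out to matter as well: replacing 3-hydroxyphenyl with 3-chlorophenyl gives a number 28.6 percentage points lower from compound 1 to compound 3 (beyond the scatter), with the 4-methylpiperazin-1-yl group and the rest of the shared core left unchanged. For the compounds shown here, until this result, the only change with a measured outcome was the one on the core, a number 18.5 percentage points lower from compound 1 to compound 2 (beyond the scatter), so the number is now seen to move with a change at either of two places on the molecule. The exchange removes the hydrogen-bond donor and the hydrogen-bond acceptor counted for hydroxy, but nothing measured on these compounds connects that count to the lower number or otherwise explains the step.

A single replacement cannot separate the loss of hydroxy from the arrival of chloro, and a methoxy or an amino group on the same aromatic carbon, or a plain hydrogen there, would be needed to tell these apart. Going by these compounds, it also remains open whether the same exchange would give a step of similar size with the piperidin-1-yl group of compound 2 in place of the 4-methylpiperazin-1-yl group.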